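Moving the methyl group from compound 3 to compound 4

The source may hold more compounds than are shown below. What is called first, only, known or untested is meant among the compounds shown, and "the series" means these compounds.

In a functional assay on HT-29 cells (Homo sapiens) for inhibition, read by CCK-8 assay, with a stated time of 24 h (a higher number here means a weaker inhibitor, a lower number a stronger inhibitor), compound 1 `Cc1cccc(-n2cc(-c3ccc(/C=C4\C(=O)Nc5ccccc54)cc3)nn2)c1` gives 3940 nM as the reference point of the series. Compound 3 `Cc1cccc(-n2cc(-c3ccc(/C=C4\C(=O)Nc5ccc(F)cc54)cc3)nn2)c1` carries a fluoro on the shared core and gives 7320 nM against that reference. Fluoro in place of hydrogen on an aromatic carbon makes a 1.9-fold higher number from compound 1 to compound 3 (0.27 log units; within the scatter) and so the two stand level on the numbers. Compound 2 `O=C1Nc2ccccc2/C1=C/c1ccc(-c2cn(-c3cccc(F)c3)nn2)cc1` reads > 20000 nM and that value is a limit of the assay.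

Compound 4 `Cc1ccc(-n2cc(-c3ccc(/C=C4\C(=O)Nc5ccc(F)cc54)cc3)nn2)cc1` differs from compound 3 by 4-methylphenyl in place of 3-methylphenyl on an aromatic nitrogen with 4-methylphenyl in place of 3-methylphenyl on an aromatic nitrogen of a five-membered aromatic ring with 3 nitrogen. The fluoro on the core stays, so only the aryl step bears directly on this change. That step is an at least 5.0-fold higher number from compound 1 to compound 2 (0.70 log units; beyond the scatter) for fluoro in place of methyl on an aromatic carbon, and it replaces the methyl instead of moving it. Among the measured compounds shown here, no measured pair moves the methyl while keeping it, so the direction is open. The expected step is a 1.0-fold higher number from compound 3 to compound 4 (0.01 log units; within the scatter) and nothing beyond the scatter is expected in this assay in either direction. The range is kept wide because an at least 5.0-fold higher number from compound 1 to compound 2 (0.70 log units; beyond the scatter) shows that a change on this aryl group can register. Compound 4 is estimated at 7500 nM with an expected range from 2500 nM to 20000 nM on this reading.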

Compound 4, half-maximal inhibitory concentration: 3980 nM
The estimate for compound 4 lay 1.9-fold (0.28 log units) above the measured number; the range from low to high includes it.
By their numbers in this assay, from the lowest: compounds 1, 4 and 3 (each within the scatter of the next). At a limit, above all of these: compound 2.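

In this assay, among the compounds shown here, the change from 3-methylphenyl to 4-methylphenyl on the aromatic nitrogen, with the fluoro on the core kept, gives a 1.8-fold lower number from compound 3 to compound 4 (0.26 log units; within the scatter); this is the first pair that keeps the methyl and changes only where it sits, and on this one pair the move does not register beyond the scatter. Compound 2, the only compound shown that replaces the methyl on this aryl group rather than moving it, reads > 20000 nM, which is a limit of the assay. Nothing given here bears on why compound 3 and compound 4 read level on the numbers.

Still open, as far as these compounds go, is whether a longer chain, an amine or a carboxylic acid in place of the methyl on this aryl group would read level with compound 1 or go the way of compound 2. Also open, from the compounds shown here alone, is how 4-methylphenyl reads on the core of compound 1 without the fluoro, and whether the level reading of this single pair holds on any other core.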